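From a Hydroxyethyl Side Chain to a Methyl

The compounds below may be only part of what the source reports. "The series", "measured", "known", "first", "only" and "open" are said of these compounds alone.

Compound 1 `C[C@H](NC(=O)CN(c1nc(Cl)nc2[nH]cnc12)C1CC1)C(=O)OCc1ccccc1` gives 36.1% in a functional assay on the whole organism (Tail, strain ICR) with Mus musculus as the target, in the tail flick test, with a stated time of 120 min, at a dose of 25 umol/kg by the oral route; on this read-out lower numbers stand for a weaker effect and higher numbers for a stronger effect at the one dose given.
Compound 2 `O=C(O)CNC(=O)CN(c1nc(Cl)nc2[nH]cnc12)C1CC1` gives 19.8% in this assay.
Compound 3 `C[C@@H](O)[C@H](NC(=O)CN(c1nc(Cl)nc2[nH]cnc12)C1CC1)C(=O)O` gives 37.6% in this assay.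

Compound 3 stands highest of the three numbers: compound 1 lies within the scatter of it, while compound 2 lies beyond the scatter below it. Compound 4 `C[C@H](NC(=O)CN(c1nc(Cl)nc2[nH]cnc12)C1CC1)C(=O)O` differs from compound 3 in one place: methyl in place of 1-hydroxyethyl on a saturated chain carbon bound to an amide-type nitrogen and a carbonyl carbon. Among the measured compounds shown here, the only measured step touching this carbon is a number 17.8 percentage points higher from compound 2 to compound 3 (beyond the scatter), where the same 1-hydroxyethyl group was added to hydrogen. Compound 4 keeps a methyl there, so it sits between the two, and a downward step that may stay within the scatter is expected, a number 8.6 percentage points lower from compound 3 to compound 4 (within the scatter). Compound 4 is therefore estimated at 29%, with a range from 14% to 44%.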

Compound 4, a percentage reported as activity, at one dose (the size of the read-out at that dose, not a potency): 28.4%
Compound 4: the middle estimate sits 0.6 percentage points above what was measured, within the range that was stated.
By their numbers in this assay, from the lowest: compounds 2, 4, 1 and 3 (each within the scatter of the next, the first and the last beyond it).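

On a saturated chain carbon bound to an amide-type nitrogen and a carbonyl carbon, methyl in place of 1-hydroxyethyl gives a number 9.2 percentage points lower from compound 3 to compound 4 (within the scatter) and methyl in place of hydrogen gives a number 8.6 percentage points higher from compound 2 to compound 4 (within the scatter) so methyl cannot be told apart from either group, although those two differ beyond the scatter. In this assay hydrogen in place of benzyl on an oxygen next to a carbonyl group gives a number 7.7 percentage points lower from compound 1 to compound 4 (within the scatter) and so shows no clear change. Nothing measured here explains these steps.

Going by these compounds, what hydroxymethyl or ethyl on this carbon would give stays open, and with it whether the hydroxyl or the added carbons of 1-hydroxyethyl matter more.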